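The source may report more compounds than this note shows. Statements on the series, on what has been measured and on what is new or still open speak of the compounds shown alone.

Of the compounds shown here, three have been measured in a functional assay on NCI-H522 cells (Homo sapiens) for cytotoxicity, with a stated time of 3 days; on this read-out higher numbers stand for weaker inhibition and lower numbers for stronger inhibition. Compound 1 `Cn1c(I)nc2ccccc21` gives 1020 nM, and compound 3 `C#Cc1nc2ccccc2s1` gives 860 nM; these two values sit within the usual scatter of each other. Compound 2 `Brc1nc2ccccc2o1` gives only a limit of the assay, > 40000 nM, which marks (the limit of > 40000 nM in this assay, at which 1 of the 3 values shown sits). Compound 4 `C#Cc1nc2ccccc2o1` shares the core of compound 2 but carries ethynyl in place of bromo on an aromatic carbon. Among the compounds with values here, no step between measured compounds is known here, so the size of this step can only be guessed. Since compound 3 carries the same ethynyl group on a related core and gives 860 nM, compound 4 is expected to move toward measurable activity, with a step of an at least 6.6-fold lower number from compound 2 to compound 4 (0.82 log units; beyond the scatter) in this assay. Compound 4 is estimated at 6000 nM, within a range of 1000 nM to 40000 nM.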

Compound 4, half-maximal inhibitory concentration: 1260 nM
Compound 4: the middle estimate sits 4.8-fold (0.68 log units) above what was measured; the range from low to high includes it.
By their numbers in this assay, from the lowest: compounds 3, 1 and 4 (each within the scatter of the next). At a limit, above all of these: compound 2.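

In this assay, ethynyl in place of bromo on this aromatic carbon, next to the ring nitrogen and next to the ring oxygen, gives an at least 31-fold lower number from compound 2 to compound 4 (1.50 log units; beyond the scatter). This single change is enough to turn a compound with no measurable value into one with a measurable value, so this carbon clearly matters for the read-out. The step has only a lower bound, as compound 2 stands at a limit of the assay: the limit of > 40000 nM in this assay, at which 1 of the 4 values shown sits.

The compounds shown leave open whether the triple bond itself matters. An amine, a nitrile or a longer chain on this carbon might do as well as ethynyl, or might not.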